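Chloro Substitution Across Two Related Amide Series

The source may report more compounds than this note shows. Statements on the series, on what has been measured and on what is new or still open speak of the compounds shown alone.

Three compounds have been measured in an assay on HEK293 cells for displacement of a labelled ligand from D(4) dopamine receptor (Homo sapiens), read by scintillation counting, with a stated time of 60 min; a lower number here means a stronger inhibitor, a higher number a weaker inhibitor:

- compound 1 `O=C(CN1CCN(c2ccccn2)CC1)Nc1cccnc1` gives 6410 nM
- compound 2 `Cc1cccc(NC(=O)CN2CCC(c3ccccc3)CC2)c1` gives 25.8 nM
- compound 3 `O=C(CN1CCN(c2ccc(Cl)cn2)CC1)Nc1cccnc1` gives 5000 nM

Compound 1 and compound 3 share a core and differ by a single change, (chloro in place of hydrogen on an aromatic carbon). This change produced a 1.3-fold lower number from compound 1 to compound 3 (0.11 log units; within the scatter), so within this pair the added chloro made no difference that can be told apart from measurement noise.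

Compound 2 belongs to a different core; how the two cores differ is not broken down here. In this assay compound 2 stands lowest of the three, with compound 3 and compound 1 both giving numbers beyond the scatter above it.

Compound 4 `Cc1cccc(NC(=O)CN2CCC(c3ccc(Cl)cc3)CC2)c1` has not yet been measured. It differs from compound 2 by chloro in place of hydrogen on an aromatic carbon. For the measured compounds named here, this is the same kind of change as the one from compound 1 to compound 3, but not the same: in compound 3 the chloro sits on a six-membered aromatic ring with 1 nitrogen, two atoms from the ring nitrogen, whereas in compound 4 it sits on a six-membered aromatic ring of carbon only. Because the earlier step was a 1.3-fold lower number from compound 1 to compound 3 (0.11 log units; within the scatter), the step from compound 2 to compound 4 in this assay is expected to be small as well, a 1.3-fold lower number from compound 2 to compound 4 (0.11 log units; within the scatter). Compound 4 is therefore estimated at 20 nM, with a likely range from 6 nM to 65 nM.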

Compound 4, inhibition constant: 115 nM
Compound 4: the middle estimate sits 5.8-fold (0.76 log units) below what was measured; the whole stated range lies below it.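

In this assay, putting chloro on the aromatic ring of compound 2 gives a 4.5-fold higher number from compound 2 to compound 4 (0.65 log units; beyond the scatter), so on this core the change is a modest but real loss of binding strength, as phenyl becomes 4-chlorophenyl. Set beside the earlier pair, the same kind of change does not carry over with the same size from one core to the other: the same change on two cores in this assay, a 1.3-fold lower number (0.11 log units; within the scatter) from compound 1 to compound 3 and a 4.5-fold higher number (0.65 log units; beyond the scatter) from compound 2 to compound 4, 5.7-fold (0.76 log units) apart, beyond the scatter of two such steps This does not show what sets the two steps apart, since there is only one pair per core and the chloro sits on a six-membered aromatic ring with 1 nitrogen in compound 3 but on a ring of carbon only in compound 4, so the ring that carries the chloro and the rest of the core change together.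

The compounds shown leave open whether fluoro, methoxy or a nitrile in place of that chloro would also raise the number on the core of compound 2, or whether the step belongs to chloro alone. They also leave open whether a chloro on a different carbon of the same ring would give a step of similar size.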